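The compounds below may be only part of what the source reports. "The series", "measured", "known", "first", "only" and "open" are said of these compounds alone.

In a physicochemical assay for solubility, measured as kinetic solubility, with a stated time of 1 h, at pH 7.4 (on this read-out lower numbers stand for lower solubility and higher numbers for higher solubility), compound 3 (`NC1=NN(c2ccc(Cl)c(Cl)c2)CC1`) gives 69000 nM as the highest of three numbers, ahead of compound 1 (`N#CCC(=O)Nc1nc(-c2ccc(Cl)c(Cl)c2)c[nH]1`) at 14000 nM and compound 2 (`N#CCC(=O)Nc1cccc(-c2ccc(Cl)c(Cl)c2)n1`) at 1000 nM with both gaps beyond the scatter. Compound 4 (`N#CCCC(=O)NC1=NN(c2ccc(Cl)c(Cl)c2)CC1`) carries (2-cyanoethyl)carbonyl in place of hydrogen on an amine nitrogen. Among the compounds with values here, no measured pair differs in one place only, so the size of this change has no direct precedent. Compound 1 at 14000 nM and compound 2 at 1000 nM both hold a carbonyl and a nitrile, and both sit lower than compound 3, on different cores. A lower number is therefore expected, with an estimated step of a 4.9-fold lower number from compound 3 to compound 4 (0.69 log units; beyond the scatter) beyond the scatter. For compound 4 the estimated value is 14000 nM (expected range 4000 nM to 45000 nM).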

Compound 4, solubility: 39000 nM
Beside the measured number, compound 4's estimate is 2.8-fold (0.44 log units) below it; measured number inside the range.
By their numbers in this assay, from the lowest: compound 2; then compound 1; then compounds 4 and 3 (each within the scatter of the next).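

In this assay the series now has its first single-place comparison: (2-cyanoethyl)carbonyl in place of hydrogen on an amine nitrogen gives a 1.8-fold lower number from compound 3 to compound 4 (0.25 log units; within the scatter) and so cannot be told apart from no change. This amine nitrogen therefore carries the group's 6 heavy atoms, including a carbonyl and a nitrile, without a step beyond the scatter. Nothing available accounts for this result.

Going by these compounds, whether an acetyl group, a longer chain or a carboxylic acid on this nitrogen would read the same remains open. This single step also cannot show whether the change behaves alike on another core.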